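A Larger Branch on the Amide Chain of Compound 2

The source may hold more compounds than are shown below. What is called first, only, known or untested is meant among the compounds shown, and "the series" means these compounds.

In an ADME assay on microsomes from liver (Rattus norvegicus) for metabolic stability, read by HPLC, using NADPH (on this read-out lower numbers stand for a shorter-lived compound and higher numbers for a longer-lived compound), compound 1 `CCn1c(C(=O)NCCN)ccc1C(CC)(CC)c1ccc(OCS(=O)(=O)c2ccccc2)c(C)c1` gives 0.582 h and compound 2 `CCn1c(C(=O)N[C@@H](C)CO)ccc1C(CC)(CC)c1ccc(OCS(=O)(=O)c2ccccc2)c(C)c1` gives 0.729 h so the two stand within the scatter of each other. Compound 3 `CCn1c(C(=O)N[C@H](CO)C(C)C)ccc1C(CC)(CC)c1ccc(OCS(=O)(=O)c2ccccc2)c(C)c1` differs from compound 2 on a saturated chain carbon bound to an amide-type nitrogen and a saturated chain carbon: isopropyl in place of methyl on a saturated chain carbon bound to an amide-type nitrogen and a saturated chain carbon is the change there. Within the data shown here, the one measured step of a 1.3-fold higher number from compound 1 to compound 2 (0.10 log units; within the scatter) is within the scatter and concerns a different exchange on the same amide-type nitrogen, so it offers only weak guidance. No shift beyond the scatter is therefore expected in this assay and the estimated step is a 1.2-fold lower number from compound 2 to compound 3 (0.08 log units; within the scatter) in size. Compound 3 is expected at 0.6 h (estimated range 0.3 h to 1.2 h).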

Compound 3, half-life in the Rattus norvegicus assay: 0.772 h
Estimate against measurement, compound 3: 1.3-fold (0.11 log units) below, and the stated range covers the measured number.
By their numbers in the Rattus norvegicus assay, from the lowest: compounds 1, 2 and 3 (each within the scatter of the next).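

In the Rattus norvegicus assay compound 3 gives 0.772 h and isopropyl in place of methyl on this saturated chain carbon gives a 1.1-fold higher number from compound 2 to compound 3 (0.02 log units; within the scatter) and 1-(hydroxymethyl)-2-methylpropyl in place of 2-aminoethyl on the amide-type nitrogen gives a 1.3-fold higher number from compound 1 to compound 3 (0.12 log units; within the scatter) so neither exchange moves the half-life beyond the scatter. In a physicochemical assay for solubility, read by HPLC, at pH 7.4 (on this read-out higher numbers stand for higher solubility and lower numbers for lower solubility), compound 2 gives 35.7 ug/mL and compound 3 gives 27.8 ug/mL and the same isopropyl exchange gives a 1.3-fold lower number from compound 2 to compound 3 (0.11 log units; within the scatter) and this too lies within the scatter. Nothing available here accounts for these readings. On these data alone, whether a longer chain or a carboxylic acid on this carbon would give a step beyond the scatter in either assay remains open.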